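From furan-2-yl to ethynyl on the shared core

This account rests on a few compounds, and the source may have more. Where it says the series, first, only, none or still open, it means among the compounds named here.

Compounds measured so far:
- Compound 1 `CSc1ncnc2c1c(-c1ccccc1)cn2[C@@H]1O[C@H](CO)[C@@H](O)[C@H]1O` gives > 100000 nM as a limit of the assay
- Compound 2 `CNc1ncnc2c1c(-c1ccco1)cn2[C@@H]1O[C@H](CO)[C@@H](O)[C@H]1O` gives 90800 nM as a measured number

These values come from an ADME assay on MRC5 cells (Homo sapiens), read by MTT assay, with a stated time of 72 h (a higher number here means a weaker inhibitor, a lower number a stronger inhibitor), and describe how strongly each compound inhibits the cells. The result for compound 1 is a limit and not a number. Going by the values given here, compound 2 therefore holds the only actual number so far, so there is no measured series against which to rank it.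

Compound 3 `C#Cc1cn([C@@H]2O[C@H](CO)[C@@H](O)[C@H]2O)c2ncnc(NC)c12` keeps the core of compound 2 but carries ethynyl in place of furan-2-yl on an aromatic carbon and has not yet been measured. Among the compounds with values here, no measured pair of compounds shows what a single change does here, so any forecast is loose. A move toward stronger inhibition in this assay seems more likely because compound 2 at 90800 nM leaves little room upward. The expected size of the change is a 3.6-fold lower number from compound 2 to compound 3 (0.56 log units; beyond the scatter) as a rough estimate. Compound 3 is estimated at 25000 nM with a range from 3000 nM to 100000 nM expected.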

Compound 3, half-maximal inhibitory concentration: > 100000 nM
Compound 3: only a limit was reported; the forecaster's own chance of this, stated with the estimate: 25%; at least 4.0-fold (0.60 log units) between middle value and limit.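

Going by these compounds alone, the swap of furan-2-yl for ethynyl, on an aromatic carbon of the five-membered aromatic ring, is the first single change that can be read at this position, and in this assay it amounts to an at least 1.1-fold higher number from compound 2 to compound 3 (0.04 log units; that floor lies within the scatter). The result for compound 3 is a limit and not a number, yet it does show that replacing the ring with ethynyl, a smaller group with no ring, brings no stronger inhibition of these cells. Whether the change weakens inhibition at all, and by how much, stays hidden because the read-out ends at a ceiling: the limit of > 100000 nM in this assay, at which 2 of the 3 values shown sit.

With a single readable pair, the compounds shown leave open whether anything placed at this position can bring the number well under that ceiling. An amine, a carboxylic acid or a longer chain on the same aromatic carbon would test this, and only a measured number, not another limit, would show how strongly the group at this position shapes inhibition in this assay.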